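The source may hold more compounds than are shown below. What is called first, only, known or untested is meant among the compounds shown, and "the series" means these compounds.

Working notes on the amide series. Within the data shown here, compound 1 `CCCCNC(=O)[C@H]1OC(n2cnc3c(N)ncnc32)[C@H](O)[C@@H]1O` carries a butyl group on the amide nitrogen of the shared core; in an assay on cell membranes for binding affinity to 2-oxoglutarate receptor 1 (Rattus norvegicus), read by radioligand binding (a higher number here means a weaker inhibitor, a lower number a stronger inhibitor), compound 1 gives 17 nM, the lowest of the two numbers so far. Among the measured compounds shown here, compound 2 `CC1CCCCC1NC(=O)[C@H]1OC(n2cnc3c(N)ncnc32)[C@H](O)[C@@H]1O` carries a 2-methylcyclohexyl group in its place and in this assay gives 69.5 nM; the step of a 4.1-fold higher number from compound 1 to compound 2 (0.61 log units; beyond the scatter) is the only measured step and points to weaker binding when the butyl is exchanged for a ring-bearing group.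

Compound 3 `COc1ccc(CNC(=O)[C@H]2OC(n3cnc4c(N)ncnc43)[C@H](O)[C@@H]2O)cc1OC` is not yet measured in this assay. Its difference from compound 1 is 3,4-dimethoxyphenyl in place of propyl on a saturated chain carbon bound to an amide-type nitrogen. For the measured compounds named here, the step from compound 1 to compound 2 is the only guide, and it too exchanged the butyl for a ring-bearing group. A weakening of similar size is therefore expected, with wide uncertainty since no aromatic amide has been measured. The expected step is a 2.9-fold higher number from compound 1 to compound 3 (0.47 log units; beyond the scatter). Compound 3 is estimated at 50 nM, within 15 nM to 170 nM.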

Compound 3, inhibition constant: 140 nM
For compound 3 the middle estimate is 2.8-fold (0.45 log units) below the measured one; low and high end bracket the measured number.
By their numbers in this assay, from the lowest: compound 1; then compounds 2 and 3 (each within the scatter of the next).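

In this assay, 3,4-dimethoxyphenyl in place of propyl on a saturated chain carbon bound to an amide-type nitrogen gives an 8.2-fold higher number from compound 1 to compound 3 (0.92 log units; beyond the scatter). This position therefore gives a higher number with an aromatic ring bearing two methoxy groups as well as with the saturated ring of the earlier change, and among the three compounds the butyl group of compound 1 keeps the lowest number. No measurement at hand accounts for this step.

Open, from the compounds shown here alone, is how much of the step belongs to the aromatic ring and how much to the two methoxy groups, which an unsubstituted phenyl or a single methoxy group would separate. Also open, going by these compounds, is whether a longer chain or a chain ending in an amine would give a lower number than the butyl group of compound 1.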